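Sulfonyl group change from compound 3 to compound 4

The compounds below may be only part of what the source reports. "The series", "measured", "known", "first", "only" and "open" are said of these compounds alone.

Measured so far in an ADME assay on HEK-293T cells (Homo sapiens) for inhibition, read by CCK-8 assay, with a stated time of 48 h, tested at 20 uM (on this read-out higher numbers stand for more inhibition of growth at the one concentration tested and lower numbers for less inhibition of growth), for this series:
- compound 1 `COc1ccc(Cc2nnc(NC(=O)/C(C#N)=C/c3ccccc3OS(=O)(=O)c3ccccc3[N+](=O)[O-])s2)cc1` gives 18%
- compound 2 `N#C/C(=C\c1ccccc1OS(=O)(=O)c1ccccc1[N+](=O)[O-])C(=O)Nc1nnc(Cc2cccc3ccccc23)s1` gives "not toxic" (no number reported) with no number reported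
- compound 3 `Cc1ccc(S(=O)(=O)Oc2ccccc2/C=C(\C#N)C(=O)Nc2nnc(Cc3ccc(F)cc3)s2)cc1` gives 16%

Compound 3 (16%) lies within the usual scatter of compound 1 (18%), and compound 2 offers no number for comparison. Compound 4 `N#C/C(=C\c1ccccc1OS(=O)(=O)c1ccccc1[N+](=O)[O-])C(=O)Nc1nnc(Cc2ccc(F)cc2)s1` is not yet measured. It keeps compound 3 apart from one change, with 2-nitrophenyl in place of 4-methylphenyl on a sulfonyl sulfur as the counted difference.

For the measured compounds named here, no measured pair isolates this change. Compound 1 already carries the 2-nitrophenyl group and gives a low value (18%), so no step beyond the scatter is expected in this assay and the direction is left open. The estimated change, a number 1 percentage points higher from compound 3 to compound 4 (within the scatter), is expected to stay within the scatter. The estimated value for compound 4 is 17% with an expected range from 5% to 32% in this read-out.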

Compound 4, percent growth inhibition at one concentration: 6%
Compound 4: the middle estimate sits 11 percentage points above what was measured; low and high end bracket the measured number.
By their numbers in this assay, from the lowest: compounds 4, 3 and 1 (each within the scatter of the next, the first and the last beyond it).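

In this assay the sulfonyl sulfur now has its first matched pair: 2-nitrophenyl in place of 4-methylphenyl gives a number 10 percentage points lower from compound 3 to compound 4 (within the scatter) and so does not clearly separate the two compounds. For the compounds shown here, with 2-nitrophenyl held constant, fluoro in place of methoxy on an aromatic carbon gives a number 12 percentage points lower from compound 1 to compound 4 (beyond the scatter) and is the first modest step to pass beyond the scatter. No measurement on hand explains either step.

Compound 2 has no number, so its place in this series cannot be read. As far as these compounds go, it remains open whether an aminophenyl or a carboxyphenyl on the sulfonyl sulfur, or a chloro or a hydroxyl in place of the fluoro, would give a step beyond the scatter.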